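Aryl appendage on the benzyl of compound 1

The compounds below may be only part of what the source reports. "The series", "measured", "known", "first", "only" and "open" are said of these compounds alone.

Compound 1 `COc1cccc(OC)c1C1CCCC(=O)N1Cc1ccccc1` gives 2420 nM in a functional assay on CHO cells for antagonist activity at Orexin/Hypocretin receptor type 1 (Homo sapiens), read by FLIPR and calcium flux (a lower number here means a stronger inhibitor, a higher number a weaker inhibitor), the highest of the two numbers at hand. Its nearest neighbour is compound 3 `COc1cccc(OC)c1C1CCCC(=O)N1Cc1ccc(-c2ccccc2)cc1`, which gives 1090 nM in this assay; the step of a 2.2-fold lower number from compound 1 to compound 3 (0.35 log units; beyond the scatter). Compound 2 `COc1cccc(OC)c1C1CCCC(=O)N1c1ccccc1` reaches only the limit of this assay, > 10000 nM, so no number is known for it (the limit of > 10000 nM in this assay, at which 1 of the 3 values shown sits). The step of an at least 4.1-fold higher number from compound 1 to compound 2 (0.61 log units; beyond the scatter).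

Compound 4 `COc1cccc(OC)c1C1CCCC(=O)N1Cc1cccc(-c2ccccn2)c1` is not yet measured. Its change from compound 1 is pyridin-2-yl in place of hydrogen on an aromatic carbon. Within the data shown here, of the measured steps only the one from compound 1 to compound 3 bears on it, since it likewise puts an aromatic ring onto the benzyl ring; that step was modest. A step of similar size and in the same direction, towards a lower number, is expected in this assay. Because the step of a 2.2-fold lower number from compound 1 to compound 3 (0.35 log units; beyond the scatter) was modest, the step is expected to be a 1.9-fold lower number from compound 1 to compound 4 (0.27 log units; within the scatter). Compound 4 is therefore estimated at 1300 nM, with a range from 500 nM to 3500 nM.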

Compound 4, half-maximal inhibitory concentration: 9 nM
The estimate for compound 4 lay 140-fold (2.16 log units) above the measured number; the measured number lies below the stated range.
By their numbers in this assay, from the lowest: compound 4; then compound 3; then compound 1. At a limit, above all of these: compound 2.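

Pyridin-2-yl in place of hydrogen, on an aromatic carbon meta to a large group, is the first change in the series with a large effect: the step is a 270-fold lower number from compound 1 to compound 4 (2.43 log units; beyond the scatter). The other aromatic ring added to the benzyl of compound 1 gave only a modest step, a 2.2-fold lower number from compound 1 to compound 3 (0.35 log units; beyond the scatter), so adding an aromatic ring does not by itself bring a gain of this size. No measurement shown gives a cause for the large step.

Compound 3 and compound 4 differ both in the added ring and in where it sits, which leaves the share of each in the gain open. Also open, from the compounds shown here alone, is whether phenyl at the place held in compound 4, or a pyridin-3-yl, an amine or a carboxylic acid there, would keep the low number.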